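The compounds below may be only part of what the source reports. "The series", "measured", "known", "first", "only" and "open" are said of these compounds alone.

Compound 1 `COc1cc(-n2ncnc2-c2ccc(C)cc2)cc(OC)c1OC` was tested in a functional assay on K562 cells (Homo sapiens) for antiproliferative activity, read by MTT assay, with a stated time of 72 h (on this read-out lower numbers stand for stronger inhibition and higher numbers for weaker inhibition), and gives > 10000 nM, which is a limit of the assay rather than a measured number. Two close relatives share this outcome. Compound 2 `COc1cc(-c2ncnn2-c2ccc(F)cc2)cc(OC)c1OC` gives > 10000 nM, again a limit. Compound 3 `COc1cc(-c2ncnn2-c2ccccc2)cc(OC)c1OC` gives > 10000 nM, also a limit. The step that the two limits leave unreadable from compound 2 to compound 3 therefore cannot be read, since both ends sit at the same limit. This is summed up by the limit of > 10000 nM in this assay, at which 3 of the 3 values shown sit.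

The unmeasured compound 4 `COc1cc(-n2ncnc2-c2ccc(F)cc2)cc(OC)c1OC` differs from compound 1 by fluoro in place of methyl on an aromatic carbon. Among the compounds with values here, no measured step bears directly on this change; the only step available is the unreadable one from compound 2 to compound 3, so no size or direction can be expected from it. Within the data shown here, with every value so far resting at the limit, compound 4 is expected to sit there too, with an estimate of 20000 nM and a range from 8000 nM to 60000 nM. That estimate means a step that the limit leaves unreadable from compound 1 to compound 4 is expected.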

Compound 4, half-maximal inhibitory concentration: > 10000 nM
Compound 4: only a limit was reported; the forecaster's own chance of this, stated with the estimate: 85%; the middle value is on the limit's open side.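

No step can be read from compound 1 to compound 4, because both ends rest on the same limit: the limit of > 10000 nM in this assay, at which 4 of the 4 values shown sit.

The compounds shown leave open how methyl, fluoro and hydrogen on the aromatic ring truly compare in this assay, and which change to the shared core, if any, would give a readable number.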